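The source may hold more compounds than are shown below. What is called first, only, known or untested is meant among the compounds shown, and "the series" means these compounds.

Working notes on the series, step from compound 3 to compound 4.

Of the compounds shown here, three carry numbers so far. Compound 1 `CC(C)(C)OC(=O)N1CCC(n2ncc3cc(-c4ccc(S(C)(=O)=O)cc4)ncc32)CC1` gives 20 nM in a functional assay on HEK293 cells for agonist activity at Glucose-dependent insulinotropic receptor (Homo sapiens), read by cAMP accumulation, with a stated time of 30 min; a lower number here means that less compound is needed, a higher number that more compound is needed for the effect. Compound 2 `CC(C)OC(=O)N1CCC(n2ncc3cc(-c4cc(F)c(C(N)=O)cc4F)ncc32)CC1` gives 52 nM in this assay, and compound 3 `CC(C)OC(=O)N1CCC(n2ncc3cc(-c4cc(F)c(C(=O)N(C)C)cc4F)ncc32)CC1` gives 46 nM in this assay. Compound 3 thus stands second highest of the three numbers: compound 2 lies within the scatter of it, while compound 1 sits beyond the scatter at a lower number.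

Compound 4 `CCNC(=O)c1cc(F)c(-c2cc3cnn(C4CCN(C(=O)OC(C)C)CC4)c3cn2)cc1F` has not been measured. It differs from compound 3 in one place: ethylamino in place of dimethylamino on a carbonyl carbon

For the measured compounds named here, the only measured step that bears on this carbonyl substituent is a 1.1-fold lower number from compound 2 to compound 3 (0.05 log units; within the scatter), amino to dimethylamino, which left the number essentially unchanged. Going by the values given here, the move now is from dimethylamino to ethylamino, a rearrangement of the same atoms on the same carbonyl carbon, and with the one comparable step lying within the scatter, no step beyond the scatter is expected in this assay in either direction.

Compound 4 is therefore expected to give about 45 nM in this assay, with a plausible range from 20 nM to 100 nM, which corresponds to an expected step of a 1.0-fold lower number from compound 3 to compound 4 (0.01 log units; within the scatter).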

Compound 4, half-maximal effective concentration: 10 nM
For compound 4 the middle estimate is 4.5-fold (0.65 log units) above the measured one; the whole stated range lies above it.
By their numbers in this assay, from the lowest: compounds 4 and 1 (each within the scatter of the next); then compounds 3 and 2 (each within the scatter of the next).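

On the carbonyl carbon, the nature of the amide substituent matters in this assay: the earlier comparison, a 1.1-fold lower number from compound 2 to compound 3 (0.05 log units; within the scatter), showed no effect from this position, whereas ethylamino in place of dimethylamino, with the same atoms joined differently, gives a 4.6-fold lower number from compound 3 to compound 4 (0.66 log units; beyond the scatter). The other new comparison, ethyl in place of hydrogen on the amide-type nitrogen, gives a 5.2-fold lower number from compound 2 to compound 4 (0.72 log units; beyond the scatter), so among these three amides only the one that carries both an ethyl and the amide hydrogen stands apart: compound 2 has the amide hydrogen without the ethyl, compound 3 has two methyl groups on the nitrogen and no amide hydrogen, and these two remain within the scatter of each other. Nothing available on these compounds gives a reason for this step.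

From the compounds shown here alone, it remains open whether the lower number needs ethyl specifically or would also appear with methylamino, propylamino or cyclopropylamino on the same carbonyl carbon. A longer chain, or one ending in a hydroxyl or an amine, would show how far this position tolerates growth beyond ethyl.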